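Chloro in Place of Methyl on Two Related Cores

The source may hold more compounds than are shown below. What is called first, only, known or untested is meant among the compounds shown, and "the series" means these compounds.

Compound 1 `CCOC(=O)c1c(-c2c(Cl)c3cc(C)ccc3oc2=O)nn(-c2cccc(C)c2)c1C(=O)OCC`: 115000 nM
Compound 2 `CCOC(=O)c1c(-c2c(Cl)c3cc(C)ccc3oc2=O)nn(-c2cccc(Cl)c2)c1C(=O)OCC`: 128000 nM
Compound 3 `CCOC(=O)c1c(-c2cc3cc(OC)ccc3oc2=O)nn(-c2cccc(C)c2)c1C(=O)OCC`: 102000 nM

All three were tested in a functional assay on A549 cells (Homo sapiens) for cytotoxicity, read by MTT assay, with a stated time of 48 h; a lower number here means a stronger inhibitor, a higher number a weaker inhibitor. From compound 1 to compound 2 the change is chloro in place of methyl on an aromatic carbon, and it gave a 1.1-fold higher number from compound 1 to compound 2 (0.05 log units; within the scatter). Compound 3 carries a different core from compound 1; the difference between the two cores is not broken down here. Compound 4 `CCOC(=O)c1c(-c2cc3cc(OC)ccc3oc2=O)nn(-c2cccc(Cl)c2)c1C(=O)OCC` differs from compound 3 by chloro in place of methyl on an aromatic carbon, and the surroundings of the place are the same in both pairs, so this is the same change made on the core of compound 3. Since compound 1 and compound 2 sit within the scatter of each other, compound 4 is expected to show a 1.1-fold higher number from compound 3 to compound 4 (0.04 log units; within the scatter), resting on compound 2 giving 128000 nM. Compound 4 is therefore estimated at 112000 nM, likely between 70000 nM and 180000 nM.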

Compound 4, half-maximal inhibitory concentration: 148000 nM
Beside the measured number, compound 4's estimate is 1.3-fold (0.12 log units) below it, and the stated range covers the measured number.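

In this assay, chloro in place of methyl on the core of compound 3 gave a 1.5-fold higher number from compound 3 to compound 4 (0.16 log units; within the scatter), and this step can be set beside the earlier one: the same change on two cores in this assay, a 1.1-fold higher number (0.05 log units; within the scatter) from compound 1 to compound 2 and a 1.5-fold higher number (0.16 log units; within the scatter) from compound 3 to compound 4, 1.3-fold (0.12 log units) apart, within the scatter of two such steps. The change therefore reads the same on both cores, staying within the scatter each time. This shows only that swapping 3-methylphenyl for 3-chlorophenyl does little on either core in this assay; with steps this small, two pairs cannot show that the cores respond alike in any finer sense, or that the result would hold on a further core.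

The compounds shown leave open whether an amine or a methoxy group at that place would move the number beyond the scatter. They also leave open what a carboxylic acid in place of the ethyl esters would do.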